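The compounds below may be only part of what the source reports. "The series", "measured", "known", "first", "only" and "open" are said of these compounds alone.

Compounds measured so far, in a functional assay on HEK293 cells for agonist activity at D(4) dopamine receptor (Homo sapiens), read by FLIPR; on this read-out lower numbers stand for an effect already at smaller amounts and higher numbers for an effect only at larger amounts of compound:

compound 1, `O=C(NCN1CCC(c2cccc[n+]2[O-])CC1)c1ccccc1`, 532 nM
compound 2, `Cc1cc(NC(=O)CN2CCC(c3cccc[n+]3[O-])CC2)ccc1F`, 18 nM
compound 3, `COc1cccc(C(=O)NCN2CCC(c3cccc[n+]3[O-])CC2)c1C`, 685 nM

Compound 2 stands lowest of the three numbers, and its gaps to compound 1 and to compound 3 both lie beyond the usual scatter, so it is the most potent of the measured compounds. For the measured compounds named here, compound 1 and compound 3 each differ from compound 2 in more than one place, so no single step between measured compounds can be drawn from these data.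

Compound 4, `Cc1cccc(C)c1NC(=O)CN1CCC(c2cccc[n+]2[O-])CC1`, has not yet been measured. It differs from compound 2 in one place: 2,6-dimethylphenyl in place of 4-fluoro-3-methylphenyl on an amide-type nitrogen. The exchanged group keeps the same size and the same lack of donors and acceptors, so the change is a rearrangement of the substituents on that ring rather than an addition or a loss.

Going by the values given here, with no measured step to lean on, a small to moderate rise in the number is expected in this assay, within or a little beyond the scatter. For compound 4 the expected step is a 3.3-fold higher number from compound 2 to compound 4 (0.52 log units; beyond the scatter). Compound 4 is estimated at 60 nM, with a likely range from 15 nM to 250 nM.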

Compound 4, half-maximal effective concentration: 346 nM
The estimate for compound 4 lay 5.8-fold (0.76 log units) below the measured number; the whole stated range lies below it.
By their numbers in this assay, from the lowest: compound 2; then compounds 4, 1 and 3 (each within the scatter of the next).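

In this assay the place on the amide-type nitrogen proves sensitive: putting 2,6-dimethylphenyl in place of 4-fluoro-3-methylphenyl gives a 19-fold higher number from compound 2 to compound 4 (1.28 log units; beyond the scatter), a large step. The two groups have the same heavy-atom count, the same kind of aromatic ring and no hydrogen-bond donors or acceptors, so these counts alone do not predict the number at this place. No measurement given here explains why the number rises so sharply.

The change swaps a fluorine for a methyl and rearranges the ring substituents at once, so the compounds shown cannot separate these two parts. On these data alone, how a ring carrying chlorine, or a cyclohexyl group in place of the aromatic ring, would behave at this place also remains open.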